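Dropping One Chloro Group From Compound 1

The source may report more compounds than this note shows. Statements on the series, on what has been measured and on what is new or still open speak of the compounds shown alone.

compound 1, `CC(=O)n1nc(C)c(-c2ccc(Cl)c(Cl)c2)c1N`: > 100000 nM
compound 2, `Cc1nn(C(=O)C2CC2)c(N)c1-c1ccc(Cl)c(Cl)c1`: > 100000 nM
compound 3, `Cc1nn(C(=O)C2CCC2)c(N)c1-c1ccc(Cl)c(Cl)c1`: > 100000 nM

In an assay on Sf9 cells for inhibition of inhibitor of nuclear factor kappa-B kinase subunit epsilon (Homo sapiens), read by ADP-Glo, with a stated time of 60 min (a lower number here means a stronger inhibitor, a higher number a weaker inhibitor), compound 1 gives > 100000 nM, and this is a limit of the assay rather than a measured number. Compound 2 gives > 100000 nM, again a limit. Compound 3 gives > 100000 nM, also a limit. All three therefore sit at the limit of > 100000 nM in this assay, at which 3 of the 3 values shown sit. The three changes among them, a cyclopropyl or cyclobutyl in place of the methyl on the carbonyl carbon, leave a step that the two limits leave unreadable from compound 1 to compound 2, a step that the two limits leave unreadable from compound 1 to compound 3 and a step that the two limits leave unreadable from compound 2 to compound 3, so none of them can be sized.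

Compound 4, `CC(=O)n1nc(C)c(-c2cccc(Cl)c2)c1N`, differs from compound 1 by hydrogen in place of chloro on an aromatic carbon. Going by the values given here, no measured step touches this six-membered aromatic ring of carbon only, so the measured steps give no guidance on its size or direction in this assay. With compound 1 at > 100000 nM, compound 4 is expected to stay near that same limit, so a step that the limit leaves unreadable from compound 1 to compound 4 is expected to be nothing readable. The estimate for compound 4 is 150000 nM, within 50000 nM to 500000 nM.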

Compound 4, half-maximal inhibitory concentration: > 100000 nM
Compound 4: only a limit was reported (the forecaster's own chance of this, stated with the estimate: 85%); the middle value lies beyond the limit too.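

In this assay compound 4 gives > 100000 nM, a limit and not a number. Compound 1 also stands at a limit, so the change from compound 1 to compound 4 cannot be sized. The compounds shown leave open what change to the shared core would give a readable value: the limit of > 100000 nM in this assay, at which 4 of the 4 values shown sit.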